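A few compounds are considered here, and "the series" means these few. Any claim that something is new, unique, unknown or untested is made for them only; others in the source may bear on it.

Measured so far in a functional assay on SF-539 cells (Homo sapiens) for cytotoxicity, read by sulforhodamine B assay, with a stated time of 48 h; on this read-out higher numbers stand for weaker inhibition of growth and lower numbers for stronger inhibition of growth:
compound 1, `ClCc1ccccc1Cn1cnc2c(Cl)nc(Cl)nc21`: 1470 nM
compound 2, `ClCc1cccc(Cn2cnc3c(Cl)nc(Cl)nc32)c1`: 2180 nM
compound 3, `Nc1nc(Cl)c2ncn(Cc3ccccc3CCl)c2n1`: 18200 nM

Compound 1 and compound 2 share the same atoms joined differently; the difference between the two cores is not broken down here, and their values in this assay lie within the usual scatter of each other. Compound 3 is compound 1 with one change: amino in place of chloro on an aromatic carbon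
in words: amino in place of chloro on an aromatic carbon
That change gave a 12-fold higher number from compound 1 to compound 3 (1.09 log units; beyond the scatter), a clear weakening of growth inhibition.

Compound 4, `Nc1nc(Cl)c2ncn(Cc3cccc(CCl)c3)c2n1`, is still to be measured. It stands to compound 2 as compound 3 stands to compound 1, carrying the same change: amino in place of chloro on an aromatic carbon
in words: amino in place of chloro on an aromatic carbon
Because the earlier step was a 12-fold higher number from compound 1 to compound 3 (1.09 log units; beyond the scatter), and compound 2 starts near compound 1 in this assay, a step of similar size is expected here, an 11-fold higher number from compound 2 to compound 4 (1.06 log units; beyond the scatter). This rests on a single earlier example, so the range is kept wide. Compound 4 is therefore estimated at 25000 nM, with a likely span from 9000 nM to 70000 nM.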

Compound 4, concentration for 50% growth inhibition: 4670 nM
Beside the measured number, compound 4's estimate is 5.4-fold (0.73 log units) above it; the whole stated range lies above it.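

In this assay, putting amino in place of chloro again weakened growth inhibition, with a 2.1-fold higher number from compound 2 to compound 4 (0.33 log units; beyond the scatter), so the direction of the change carried over from one core to the other. The size did not carry over, and the two steps differ by more than the usual scatter of repeated measurements: the same change on two cores in this assay, a 12-fold higher number (1.09 log units; beyond the scatter) from compound 1 to compound 3 and a 2.1-fold higher number (0.33 log units; beyond the scatter) from compound 2 to compound 4, 5.8-fold (0.76 log units) apart, beyond the scatter of two such steps. So these two cores, which hold the same atoms joined differently, show that the direction of this change held while its size depended on the core, but they do not show why the size differs or whether the direction would hold on any further core.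

The compounds shown leave open what other groups would do on the aromatic carbon between two ring nitrogen atoms, such as a methylamino or a methoxy group in place of the amino. They also leave open whether a larger group there, such as a dimethylamino, would show the same dependence on the core.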